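Returning a sulfonyl group on the anilide ring

The compounds below may be only part of what the source reports. "The series", "measured", "known", "first", "only" and "open" are said of these compounds alone.

Compound 2 `CCSc1ccc(Nc2ncnc(N3CCC(c4nc(C(C)C)no4)CC3)c2[N+](=O)[O-])cc1` gives 110 nM in a functional assay for agonist activity at Glucose-dependent insulinotropic receptor (Homo sapiens) (on this read-out higher numbers stand for an effect only at larger amounts of compound and lower numbers for an effect already at smaller amounts), the higher of the two measured numbers. Compound 1 `CC(C)c1noc(C2CCN(c3ncnc(Nc4ccc(S(=O)(=O)C(C)C)cc4)c3[N+](=O)[O-])CC2)n1` gives 7.8 nM in this assay, and the step of a 14-fold higher number from compound 1 to compound 2 (1.15 log units; beyond the scatter) is the only one measured. Compound 3 `CC(C)c1noc(C2CCN(c3ncnc(Nc4ccc(S(C)(=O)=O)c(F)c4)c3[N+](=O)[O-])CC2)n1` is unmeasured; the change is 3-fluoro-4-(methylsulfonyl)phenyl in place of 4-(ethylsulfanyl)phenyl on a nitrogen on an aromatic ring, so a methylsulfonyl group stands where compound 1 carried isopropylsulfonyl. Because the step of a 14-fold higher number from compound 1 to compound 2 (1.15 log units; beyond the scatter) was large, a lower number is expected for compound 3, a step of about an 11-fold lower number from compound 2 to compound 3 (1.04 log units; beyond the scatter). Compound 3 is therefore estimated at 10 nM, within 3 nM to 35 nM.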

Compound 3, half-maximal effective concentration: 3.4 nM
For compound 3 the middle estimate is 2.9-fold (0.47 log units) above the measured one; measured number inside the range.
By their numbers in this assay, from the lowest: compound 3; then compound 1; then compound 2.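

Replacing the 4-(ethylsulfanyl)phenyl group with 3-fluoro-4-(methylsulfonyl)phenyl gave a 32-fold lower number from compound 2 to compound 3 (1.51 log units; beyond the scatter), so a second sulfonyl-bearing ring also stands far below the sulfanyl compound. Replacing 4-(isopropylsulfonyl)phenyl with the same group gave a 2.3-fold lower number from compound 1 to compound 3 (0.36 log units; beyond the scatter), a modest step, which shows that the isopropyl group is not needed at this position. No measurement offered here explains either step.

As far as these compounds go, the fluorine and the methyl group enter together, so their separate shares remain unknown. From the compounds shown here alone, whether a sulfonamide could replace the methylsulfonyl group also stays open.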